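Oxime Hydroxyl to 4-Methylphenyl Ether: Expected Partition

This account rests on a few compounds, and the source may have more. Where it says the series, first, only, none or still open, it means among the compounds named here.

Compound 1 `CCO/N=C/Nc1cc(Cl)c([S+]([O-])CC)c(Cl)c1` gives 2.9 in a physicochemical assay for lipophilicity, measured as octanol-water partition; on this read-out higher numbers stand for higher lipophilicity and lower numbers for lower lipophilicity.
Compound 2 `CCCOc1c(Cl)cc(N/C=N/OCC)cc1Cl` gives 4.6 in this assay.
Compound 3 `C#CCc1c(Cl)cc(N/C=N/O)cc1Cl` gives 2.8 in this assay.

Compound 3 stands lowest of the three, with compound 1 within the scatter of it and compound 2 well above it. Compound 4 `C#CCc1c(Cl)cc(N/C=N/Oc2ccc(C)cc2)cc1Cl` differs from compound 3 by 4-methylphenyl in place of hydrogen on an oxygen. Within the data shown here, no measured step touches this oxygen; the one step available, a number 1.70 log units higher from compound 1 to compound 2 (beyond the scatter), concerns a group on an aromatic carbon and serves only as a yardstick for how far a single exchange can move this read-out. Since a whole aromatic ring enters where only a hydrogen left, compound 4 is expected to rise by a number 2.70 log units higher from compound 3 to compound 4 (beyond the scatter), a step larger than that yardstick. The estimate for compound 4 is 5.5, between 4.8 and 6.2.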

Compound 4, partition coefficient: 4.8
Estimate against measurement, compound 4: 0.70 log units above; low and high end bracket the measured number.
By their numbers in this assay, from the lowest: compounds 3 and 1 (each within the scatter of the next); then compounds 2 and 4 (each within the scatter of the next).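

In this assay, the exchange of hydrogen for 4-methylphenyl on the oxygen gives a number 2.00 log units higher from compound 3 to compound 4 (beyond the scatter) with the rest of the molecule unchanged. The earlier compounds shown here showed a large step only for a group on an aromatic carbon, whereas this one shows that a single exchange on this oxygen can also produce a large step. Nothing measured here bears on the origin of this step.

As far as these compounds go, how much of the rise belongs to the ring and how much to its methyl remains open. From the compounds shown here alone, it is also open how an unsubstituted phenyl, an ethyl or a longer chain on this oxygen would compare.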